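Swapping Trifluoromethyl for Chloro on a Diaryl Urea

A few compounds are considered here, and "the series" means these few. Any claim that something is new, unique, unknown or untested is made for them only; others in the source may bear on it.

Two diaryl ureas on a shared core have been measured in a functional assay on RPMI-8226 cells (Homo sapiens) for inhibition, read by sulforhodamine B assay, with a stated time of 48 h; on this read-out higher numbers stand for weaker inhibition of growth and lower numbers for stronger inhibition of growth. Compound 1 `COc1cc2cc(Oc3ccc(NC(=O)Nc4cccc(C(F)(F)F)c4)cc3)c(C)nc2cc1OC` gives 2960 nM in this assay. Compound 2 `COc1cc2cc(Oc3ccc(NC(=O)Nc4ccc(Cl)c(C(F)(F)F)c4)cc3)c(C)nc2cc1OC` gives 1650 nM in this assay. Among the measured compounds shown here, the one single-point step recorded is a 1.8-fold lower number from compound 1 to compound 2 (0.25 log units; within the scatter), so the two numbers cannot be told apart with confidence. For the measured compounds named here, compound 2 holds the lower of the two numbers, with compound 1 its only neighbour at a gap that sits inside the scatter.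

Compound 3 `COc1cc2cc(Oc3ccc(NC(=O)Nc4ccc(Cl)c(Cl)c4)cc3)c(C)nc2cc1OC` is not yet measured. It differs from compound 2 by chloro in place of trifluoromethyl on an aromatic carbon. Going by the values given here, no measured step covers this exchange of trifluoromethyl for chloro; the only step seen, from compound 1 to compound 2, concerns a different exchange and was itself within the scatter. The two numbers in hand therefore give no ground for expecting compound 3 to move beyond the scatter in either direction. The expected step is a 1.2-fold higher number from compound 2 to compound 3 (0.08 log units; within the scatter). For compound 3 the estimate in this assay is 2000 nM, with a range from 800 nM to 5000 nM.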

Compound 3, concentration for total growth inhibition: 5730 nM
Compound 3: middle estimate off by 2.9-fold (0.46 log units), on the low side; measured number outside the range, above it.
By their numbers in this assay, from the lowest: compounds 2, 1 and 3 (each within the scatter of the next, the first and the last beyond it).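

In this assay, among the compounds shown here, the exchange of trifluoromethyl for chloro gives the first step in this small set that clears the scatter: a 3.5-fold higher number from compound 2 to compound 3 (0.54 log units; beyond the scatter). This shows that the position on the 4-chloro-3-(trifluoromethyl)phenyl group is not indifferent to what it carries, since replacing a group of four heavy atoms with a single chlorine shifts the read-out towards weaker inhibition of growth, although the shift is only modest, and the other new comparison, a 1.9-fold higher number from compound 1 to compound 3 (0.29 log units; within the scatter), does not separate the 3,4-dichlorophenyl compound from the 3-(trifluoromethyl)phenyl compound. No measurement here explains why the exchange shifts the number.

From the compounds shown here alone, it remains open how other groups at this position would compare, such as a methyl group, a methoxy group or an amine, and whether any of them would match trifluoromethyl or fall short of it as chloro does. It is also unclear whether the same exchange would give a step of similar size without the chloro group that sits ortho to this position in compound 2 and compound 3.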